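The source may hold more compounds than are shown below. What is called first, only, known or untested is meant among the compounds shown, and "the series" means these compounds.

Compound 1, `CNc1nc2c(SCc3ccccc3)ncnc2n1C1O[C@H](CO)[C@@H](O)[C@H]1O`, carries a methylamino group on the shared core and in an assay on cell membranes for binding affinity to Equilibrative nucleoside transporter 1 (Homo sapiens) (a higher number here means a weaker inhibitor, a lower number a stronger inhibitor), compound 1 gives 28 nM. Compound 2, `CCCCCNc1nc2c(SCc3ccccc3)ncnc2n1C1O[C@H](CO)[C@@H](O)[C@H]1O`, gives 2.3 nM, and compound 3, `CCCCCCNc1nc2c(SCc3ccccc3)ncnc2n1C1O[C@H](CO)[C@@H](O)[C@H]1O`, gives 3.7 nM. Among these three numbers compound 3 stands second highest: its nearest neighbour is compound 2, within the scatter, and its furthest is compound 1, beyond it.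

Compound 4, `CCC(C)CNc1nc2c(SCc3ccccc3)ncnc2n1C1O[C@H](CO)[C@@H](O)[C@H]1O`, is reached from compound 3 by a single change: sec-butyl in place of pentyl on a saturated chain carbon bound to a nitrogen on an aromatic ring. Two measured steps speak to the worth of a chain at this nitrogen, a 12-fold lower number from compound 1 to compound 2 (1.09 log units; beyond the scatter) and a 7.6-fold lower number from compound 1 to compound 3 (0.88 log units; beyond the scatter). Once a chain of several carbons is in place, lengthening it makes little difference: a 1.6-fold higher number from compound 2 to compound 3 (0.21 log units; within the scatter). Compound 4 keeps a chain of four carbons, now branched, so the question is only whether branching costs anything. Going by the values given here, nothing among the measured compounds tests branching, so no step beyond the scatter is expected in this assay, in either direction. Compound 4 is therefore estimated at 4 nM, with a likely range from 1.5 nM to 12 nM, which means an expected step of a 1.1-fold higher number from compound 3 to compound 4 (0.03 log units; within the scatter).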

Compound 4, inhibition constant: 3.6 nM
Beside the measured number, compound 4's estimate is 1.1-fold (0.05 log units) above it; low and high end bracket the measured number.
By their numbers in this assay, from the lowest: compounds 2, 4 and 3 (each within the scatter of the next); then compound 1.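

Going by these compounds alone, the branched chain, a shape the earlier compounds did not test, shows no cost at this position: sec-butyl in place of pentyl on a saturated chain carbon bound to a nitrogen on an aromatic ring gives a 1.0-fold lower number from compound 3 to compound 4 (0.01 log units; within the scatter), and sec-butyl in place of butyl gives a 1.6-fold higher number from compound 2 to compound 4 (0.19 log units; within the scatter), so in this assay compounds 2, 3 and 4 cannot be told apart. The advantage of these chains over the methylamino group of compound 1 also survives the branch, with a 7.8-fold lower number from compound 1 to compound 4 (0.89 log units; beyond the scatter), so this position accepts the branched chain as well as the two straight ones shown. Nothing available explains why the branched and straight chains fall so close together.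

The compounds shown leave open whether this tolerance extends to a cyclohexyl or benzyl group on the same nitrogen, or to a much longer chain such as decyl. They also leave open whether a chain ending in a hydroxyl group or an amine would stay within the scatter of compound 4.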